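The compounds below may be only part of what the source reports. "The series", "measured", "known", "first", "only" and "open" are said of these compounds alone.

Two compounds of a shared core, each bearing an ethyl ester on a side chain, have been tested in a functional assay on the whole organism (strain albino) for inhibition, with Rattus norvegicus as the target, read by paw edema, with stated times of 30 min and 1 h, at a dose of 5 mg/kg by the oral route; on this read-out lower numbers stand for less inhibition and higher numbers for more inhibition at the one dose given (going by the name of the read-out). Compound 1, `CCOC(=O)Cc1nc(N)n(C(=O)c2ccc(Br)cc2)n1`, carries an acyl group on the ring nitrogen and in this assay compound 1 gives 34.8%. Compound 2, `CCOC(=O)Cc1n[nH]c(NC(=O)c2ccccc2)n1`, carries instead an amide on the ring, and in this assay compound 2 gives 26.8%. Among the compounds with values here, the two numbers lie within the usual scatter of each other, so nothing can be said of an order between compound 1 and compound 2, and no step between them is worked out here.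

Compound 3, `CCOC(=O)Cc1n[nH]c(NC(=O)c2ccc([N+](=O)[O-])cc2)n1`, has not yet been measured. It differs from compound 2 in one place: nitro in place of hydrogen on an aromatic carbon. Within the data shown here, there is no measured pair in this set that shows what such a change does, so the expectation for compound 3 rests on compound 2 alone, and a step from compound 2 to compound 3 of no more than the scatter is expected, a number 3.2 percentage points higher from compound 2 to compound 3 (within the scatter), in no particular direction. On that basis compound 3 is estimated to give 30% in this assay, with a range from 15% to 45%.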

Compound 3, a percentage reported as inhibition, in the whole organism at one dose (the size of the read-out at that dose, not a potency): 32.6%
Estimate against measurement, compound 3: 2.6 percentage points below; measured number inside the range.
By their numbers in this assay, from the lowest: compounds 2, 3 and 1 (each within the scatter of the next).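

In this assay, nitro in place of hydrogen on an aromatic carbon of the six-membered aromatic ring of carbon only, para to a large group, gives a number 5.8 percentage points higher from compound 2 to compound 3 (within the scatter), so this position carries the nitro group without a change in the read-out that can be told apart from the scatter. Within the data shown here, the earlier compounds could not show this, since they differ in more than one place and offered no step at all; this pair is the first in which a single change can be read, and at the one dose given it does not separate hydrogen from nitro. Nothing measured here bears on why the two compounds stand so close, and nothing ties the result to any property of the nitro group.

The compounds shown leave open whether an amine, a methoxy group or a carboxylic acid at the same place would stay within the scatter of compound 2 as nitro does. They also leave open what happens when the ethyl ester on the side chain gives way to a carboxylic acid or a longer chain while the benzoyl amide stays as it is.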